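The source may report more compounds than this note shows. Statements on the series, on what has been measured and on what is new or still open speak of the compounds shown alone.

In an ADME assay on HEK293 cells (Homo sapiens) for cytotoxicity, read by resazurin assay, with a stated time of 48 h (on this read-out lower numbers stand for higher toxicity in this test and higher numbers for lower toxicity in this test), compound 1 `O=S(=O)(Nc1ccc(-c2nc3ccccc3o2)cc1)c1cccc(Cl)c1` reaches only a limit of the test, > 100000 nM. Compound 2 `C=Cc1ccc(S(=O)(=O)Nc2ccc(-c3nc4ccccc4o3)cc2)cc1` likewise stops at a limit, > 100000 nM. For the measured compounds named here, compound 3 `O=S(=O)(Nc1ccc(-c2nc3ccccc3o2)cc1)c1ccc(C(F)(F)F)cc1` is the single compound with a number in this assay, 94000 nM, and so it stands as the only readable point among the three. The values of compound 1 and compound 2 are limits, as the limit of > 100000 nM in this assay, at which 2 of the 3 values shown sit, records. Of the measured steps, a step that the two limits leave unreadable from compound 1 to compound 2 is unreadable between two limits, and an at least 1.0-fold lower number from compound 2 to compound 3 (0.02 log units; that floor lies within the scatter) is a floor that lies within the scatter. Compound 4 `O=S(=O)(Nc1ccc(-c2nc3ccccc3o2)cc1)c1ccc(Cl)cc1`, still unmeasured, differs from compound 3 by chloro in place of trifluoromethyl on an aromatic carbon, a smaller group entering where the trifluoromethyl left, on the same aromatic carbon. Neither measured step points to a direction in this assay, and both earlier changes on that aromatic ring left the values near the top of the range. One therefore expects no step beyond the scatter, a 1.1-fold higher number from compound 3 to compound 4 (0.03 log units; within the scatter), with a fair chance of a limit again. For compound 4 the estimate in this assay is 100000 nM, expected to fall between 50000 nM and 200000 nM.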

Compound 4, half-maximal cytotoxic concentration: > 100000 nM
Compound 4: only a limit was reported; the forecaster's own chance of this, stated with the estimate: 60%; the middle value sits exactly at the limit.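

In this assay compound 4 gives > 100000 nM, which is a limit of the test and not a number. Chloro in place of trifluoromethyl on this aromatic carbon, para to a large group, gives an at least 1.0-fold higher number from compound 3 to compound 4 (0.02 log units; that floor lies within the scatter), so this exchange of one heavy atom for four shows no change that can be told from the scatter. The steps reaching compound 4 from compound 1 and from compound 2 lie between two limits and cannot be read, and most of the set now sits at one mark: the limit of > 100000 nM in this assay, at which 3 of the 4 values shown sit.

For the compounds shown here, compound 3 remains the only compound with a number, so no direction can be read for this position. From the compounds shown here alone, whether an amine or a carboxylic acid on this aromatic carbon, or a change in the shared core, would give a readable value stays open.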